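Swapping amino for dimethylamino on a shared core

A few compounds are considered here, and "the series" means these few. Any claim that something is new, unique, unknown or untested is made for them only; others in the source may bear on it.

Measured so far in an ADME assay on HEp-2 cells (Homo sapiens) for cytotoxicity (on this read-out higher numbers stand for lower toxicity in this test and lower numbers for higher toxicity in this test), are three compounds:
- compound 1 (`CC(C)CCn1c(Cn2c(=O)n(C(C)C)c3ccccc32)nc2cc(CO)ccc21`) gives 31600 nM
- compound 2 (`CC(C)CCn1c(Cn2c(=O)n(C(C)C)c3ccccc32)nc2cc(CF)ccc21`) gives 37300 nM
- compound 3 (`CC(C)CCn1c(Cn2c(=O)n(C(C)C)c3ccccc32)nc2ccc(CN)cc21`) gives 28100 nM

Compound 3 stands level with the other two, as all three values lie within the usual scatter of repeated measurements. Compound 4 (`CC(C)CCn1c(Cn2c(=O)n(C(C)C)c3ccccc32)nc2ccc(CN(C)C)cc21`) has not yet been measured. It differs from compound 3 by a single change (dimethylamino in place of amino on a saturated chain carbon bound to an aromatic carbon), with dimethylamino in place of amino on a saturated chain carbon bound to an aromatic carbon.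

Among the compounds with values here, the only measured step on a carbon of this kind is a 1.2-fold higher number from compound 1 to compound 2 (0.07 log units; within the scatter) and it swaps hydroxy for fluoro, so it is only an indirect guide. Within the data shown here, no measured step involves dimethylamino. A shift beyond the scatter in this assay is therefore not expected, and no direction can be given. The expected result is a 1.0-fold lower number from compound 3 to compound 4 (0.00 log units; within the scatter) and would count as no real change. Compound 4 is estimated at 28000 nM with an expected range from 14000 nM to 50000 nM for a first measurement.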

Compound 4, half-maximal cytotoxic concentration: 26700 nM
Compound 4: middle estimate off by 1.0-fold (0.02 log units), on the high side; the measured number falls inside the stated range.
By their numbers in this assay, from the lowest: compounds 4, 3, 1 and 2 (each within the scatter of the next).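

In this assay, putting dimethylamino in place of amino on a saturated chain carbon bound to an aromatic carbon makes no real difference (a 1.1-fold lower number from compound 3 to compound 4 (0.02 log units; within the scatter)). Dimethylamino has more heavy atoms than amino and no hydrogen-bond donor, yet this difference does not separate compound 3 from compound 4 in this test, so the read-out tolerates this particular swap. Nothing measured here bears on the reason for this result.

Still open, going by these compounds, is whether any group on this carbon can move the number beyond the usual scatter, for example a carboxylic acid or a morpholine ring. It is also unclear whether an acetamide, which keeps a hydrogen on the nitrogen but adds a carbonyl, would give a similar value.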